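A few compounds are considered here, and "the series" means these few. Any claim that something is new, unique, unknown or untested is made for them only; others in the source may bear on it.

In an ADME assay on MONO-MAC-6 cells (Homo sapiens), read by MTT assay, with a stated time of 72 h (on this read-out higher numbers stand for weaker inhibition and lower numbers for stronger inhibition), compound 1 (`CC12CCC(C/C1=N\NC(=O)c1ccc(C(F)(F)F)cc1)C2(C)C`) gives > 100000 nM as a limit and not a number. Compound 3 (`O=C(N/N=C/c1ccc(Cl)cc1)c1ccc(C(F)(F)F)cc1`) reads > 100000 nM and so stands at the limit of > 100000 nM in this assay, at which 2 of the 3 values shown sit, with no number of its own. Compound 2 (`O=C(N/N=C/c1cc(Cl)ccc1O)c1ccc(C(F)(F)F)cc1`) gives a true number, 10300 nM in this assay terms. Compound 4 (`O=C(N/N=C/c1ccccc1O)c1ccc(C(F)(F)F)cc1`) has 2-hydroxyphenyl in place of 4-chlorophenyl on a carbon with a double bond to nitrogen. Among the compounds with values here, no measured step sizes this change. Within the data shown here, with compound 2 at 10300 nM as the only reading that is a number, compound 4 is expected to show stronger inhibition than compound 3 and land near that reading. The expected move an at least 5.0-fold lower number from compound 3 to compound 4 (0.69 log units; beyond the scatter) is an estimate resting on that single reading. Compound 4 is estimated at 20000 nM (expected range 5000 nM to 80000 nM).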

Compound 4, half-maximal inhibitory concentration: 1700 nM
Estimate against measurement, compound 4: 12-fold (1.07 log units) above, and the stated range ends above it.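

In this assay, 2-hydroxyphenyl in place of 4-chlorophenyl on a carbon with a double bond to nitrogen gives an at least 58-fold lower number from compound 3 to compound 4 (1.76 log units; beyond the scatter), the first sign that this place can turn a limit reading into a numbered one. Hydrogen in place of chloro on an aromatic carbon then gives a 6.1-fold lower number from compound 2 to compound 4 (0.78 log units; beyond the scatter), so the chloro is not needed for this reading. The first step has no fixed size because compound 3 carries only a limit: the limit of > 100000 nM in this assay, at which 2 of the 4 values shown sit.

Still open, on these data alone, is whether the hydroxy group itself carries the step, or whether a methoxy group or an amine in its place would serve equally.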